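The source may report more compounds than this note shows. Statements on the series, on what has been measured and on what is new or still open speak of the compounds shown alone.

Working notes on the series. In a functional assay on HL-60 cells (Homo sapiens) for cytotoxicity, with a stated time of 24 h (on this read-out higher numbers stand for lower toxicity in this test and lower numbers for higher toxicity in this test), compound 1 (`O=C1/C(=C/c2ccccc2)CCC/C1=C\c1cccc([N+](=O)[O-])c1`) gives 3000 nM, compound 2 (`O=C1/C(=C/c2ccc(F)cc2)CCC/C1=C\c1cccc([N+](=O)[O-])c1`) gives 1000 nM and compound 3 (`CN(C)c1ccc(/C=C2\CCC/C(=C\c3cccc([N+](=O)[O-])c3)C2=O)cc1`) gives 30000 nM, the highest number of the three. Compound 4 (`COc1ccc(/C=C2\CCC/C(=C\c3cccc([N+](=O)[O-])c3)C2=O)cc1`) is still unmeasured. The change from compound 3 to compound 4 is methoxy in place of dimethylamino on an aromatic carbon, para to a large group.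

Among the compounds with values here, no measured compound carries methoxy, so the evidence is indirect. The closest steps are those involving dimethylamino: a 10-fold higher number from compound 1 to compound 3 (1.00 log units; beyond the scatter), modest, with dimethylamino in place of hydrogen, and a 30-fold higher number from compound 2 to compound 3 (1.48 log units; beyond the scatter), large, with dimethylamino in place of fluoro. The third step, a 3.0-fold lower number from compound 1 to compound 2 (0.48 log units; beyond the scatter), is modest and shows a smaller spread between the two compounds without dimethylamino. Both compounds without dimethylamino sit well below compound 3, so a modest to large move to a lower number is expected in this assay. The expected change is a 7.5-fold lower number from compound 3 to compound 4 (0.88 log units; beyond the scatter). Compound 4 is estimated at 4000 nM, with an expected range of 1200 nM to 12000 nM.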

Compound 4, half-maximal cytotoxic concentration: 7200 nM
Compound 4: middle estimate off by 1.8-fold (0.26 log units), on the low side; the range from low to high includes it.
By their numbers in this assay, from the lowest: compound 2; then compound 1; then compound 4; then compound 3.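

In this assay, within the data shown here, methoxy gives the first number at this position that falls between those of the hydrogen and dimethylamino compounds. It stays clearly below dimethylamino (a 4.2-fold lower number from compound 3 to compound 4 (0.62 log units; beyond the scatter)). It stays above hydrogen (a 2.4-fold higher number from compound 1 to compound 4 (0.38 log units; beyond the scatter)). The gap to fluoro is wider (a 7.2-fold higher number from compound 2 to compound 4 (0.86 log units; beyond the scatter)), so all four groups are now separated by steps beyond the scatter, and both methoxy and dimethylamino give higher numbers than hydrogen, while fluoro in compound 2 goes against that direction. Nothing measured here bears on why the groups fall in this order.

Still open, on these data alone, is whether a longer chain such as ethoxy, or a hydroxyl or chloro group, would fit this order at this position. As far as these compounds go, the nitro-bearing side stays the same throughout, so whether the order holds with an amine or a carboxylic acid there also remains open.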